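The compounds below may be only part of what the source reports. "The series", "measured", "known", "first", "only" and "open" are said of these compounds alone.

Working notes on the ester and thioester series.

Compound 1 `CCOC(=O)/C=C(C)/C=C/CC(C)CCCC(C)(C)OCC` gives 6.08 in a physicochemical assay for lipophilicity; on this read-out higher numbers stand for higher lipophilicity and lower numbers for lower lipophilicity. Compound 2 `CCOC(C)(C)CCCC(C)C/C=C/C(C)=C/C(=O)OC(C)C` gives 6.49; the change methyl in place of hydrogen on a saturated chain carbon bound to an oxygen next to a carbonyl group and a saturated chain carbon produced a number 0.41 log units higher from compound 1 to compound 2 (beyond the scatter). Compound 3 `CSC(=O)/C=C(C)/C=C/CC(C)CCCC(C)C` gives 7.44, the highest of the three measured values; the difference between its core and the core of compound 1 is not broken down here.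

Compound 4 `CCSC(=O)/C=C(C)/C=C/CC(C)CCCC(C)C` has not yet been measured. It differs from compound 3 by methyl in place of hydrogen on a saturated chain carbon bound to a sulfur. This is the same kind of change as from compound 1 to compound 2, not the same: there the methyl entered on a saturated chain carbon bound to an oxygen next to a carbonyl group and a saturated chain carbon, here it enters on a saturated chain carbon bound to a sulfur. In this assay compound 4 is expected to shift by a number 0.46 log units higher from compound 3 to compound 4 (beyond the scatter), a step of about the size seen in a number 0.41 log units higher from compound 1 to compound 2 (beyond the scatter). The expected value for compound 4 is 7.9, with a range from 7.5 to 8.3.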

Compound 4, partition coefficient: 7.98
Estimate against measurement, compound 4: 0.08 log units below; the range from low to high includes it.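

In this assay, methyl in place of hydrogen on a saturated chain carbon bound to a sulfur gives a number 0.54 log units higher from compound 3 to compound 4 (beyond the scatter), the same direction as a number 0.41 log units higher from compound 1 to compound 2 (beyond the scatter), where the methyl enters on a saturated chain carbon bound to an oxygen. The change therefore moves the number the same way on both cores, but this rests on one pair per core, with the methyl at a different place in each, and does not establish transfer to any other core. Nothing shown accounts for the size of either step.

The compounds shown leave open how a longer chain such as propyl on the sulfur would read. They also leave open whether the step would hold on a core carrying an amine or a carboxylic acid.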